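Hydrazone series: removing the chloro substituent from compound 1

The source may report more compounds than this note shows. Statements on the series, on what has been measured and on what is new or still open speak of the compounds shown alone.

Compound 1 `CCCSc1nc(N/N=C/c2ccc(Cl)cc2)c2nnn(Cc3ccccc3)c2n1` and compound 2 `CCCSc1nc(N/N=C/c2cc(OC)c(OC)c(OC)c2)c2nnn(Cc3ccccc3)c2n1` share one core and differ only in the aryl group hung from the hydrazone. In a functional assay on ECa-109 cells (Homo sapiens) for antiproliferative activity, read by MTT assay, with a stated time of 72 h (a lower number here means a stronger inhibitor, a higher number a weaker inhibitor), compound 1 gives > 64000 nM, which is a limit of the assay rather than a number. Compound 2 gives 4060 nM in this assay. Of the two values known, compound 1 is the one sitting at the limit (the limit of > 64000 nM in this assay, at which 1 of the 2 values shown sits). Compound 3 `CCCSc1nc(N/N=C/c2ccccc2)c2nnn(Cc3ccccc3)c2n1` has not yet been run in this assay. It differs from compound 1 in one place: hydrogen in place of chloro on an aromatic carbon. Going by the values given here, no measured step of this kind exists, so the size of the step from compound 1 to compound 3 can only be guessed; the expectation is a step of no more than modest size, if any, in either direction. For compound 3 the estimate in this assay is 60000 nM, ranging from 15000 nM to 200000 nM, a step expected as an at least 1.0-fold lower number from compound 1 to compound 3 (0.02 log units; that floor lies within the scatter).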

Compound 3, half-maximal inhibitory concentration: > 64000 nM
Compound 3 ended at the assay's limit (the forecaster's own chance of this, stated with the estimate: 55%); at least 1.0-fold (0.02 log units) between middle value and limit.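

In this assay compound 3 gives > 64000 nM which is a limit of the assay and not a number. Compound 1 and compound 3 therefore yield no readable step, since both rest at the same limit: the limit of > 64000 nM in this assay, at which 2 of the 3 values shown sit. On these data alone, whether going from 4-chlorophenyl to phenyl changes activity at all stays open.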